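The source may report more compounds than this note shows. Statements on the series, on what has been measured and on what is new or still open speak of the compounds shown alone.

Measured compounds:
compound 1, `Oc1ccccc1-c1cc(-c2cccc(OC(F)(F)F)c2)cc(-c2ccccc2O)n1`, > 50000 nM
compound 2, `Oc1cccc(-c2cc(-c3ccccc3OC(F)(F)F)cc(-c3ccccc3O)n2)c1`, 15200 nM
compound 3, `Oc1cccc(-c2cc(-c3cccc(OC(F)(F)F)c3)cc(-c3ccccc3O)n2)c1`, 14900 nM

Of the compounds shown here, three built on one shared core have been tested in a functional assay on HeLa cells (Homo sapiens) for inhibition; a lower number here means a stronger inhibitor, a higher number a weaker inhibitor. Compound 1 reaches only the limit of this assay, > 50000 nM, and so gives no number. Compound 2 gives 15200 nM, and compound 3 gives 14900 nM; these two values sit within the scatter of each other. Compound 1 and compound 3 differ in one place, (3-hydroxyphenyl in place of 2-hydroxyphenyl on an aromatic carbon), and this change brings an at least 3.3-fold lower number from compound 1 to compound 3 (0.52 log units; beyond the scatter). The only thing known about the cause of this step is that compound 1 sits at the limit, (the limit of > 50000 nM in this assay, at which 1 of the 3 values shown sits). How the cores of compound 1 and compound 2 differ is not broken down here.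

Compound 4, `Oc1cccc(-c2cc(-c3ccccc3OC(F)(F)F)cc(-c3cccc(O)c3)n2)c1`, has not yet been measured. It arises from compound 2 by 3-hydroxyphenyl in place of 2-hydroxyphenyl on an aromatic carbon. Going by the values given here, this is the same kind of change as the one from compound 1 to compound 3, but not the same: there the place was meta to a 2-hydroxyphenyl group, here it is meta to a 3-hydroxyphenyl group. On the strength of that earlier step, compound 4 is expected to give a lower number than compound 2, by about a 3.0-fold lower number from compound 2 to compound 4 (0.48 log units; beyond the scatter). Going by these compounds, because the value of compound 1 is only a limit, > 50000 nM, the true size of the earlier step is unknown, and the expectation is accordingly wide. Compound 4 is estimated at 5000 nM in this assay, with a likely range from 1500 nM to 20000 nM.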

Compound 4, half-maximal inhibitory concentration: 16700 nM
Compound 4: middle estimate off by 3.3-fold (0.52 log units), on the low side; the measured number falls inside the stated range.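

In this assay, putting 3-hydroxyphenyl in place of 2-hydroxyphenyl on the core of compound 2 brings a 1.1-fold higher number from compound 2 to compound 4 (0.04 log units; within the scatter), so on this core the two compounds cannot be told apart. The change therefore does not carry over from one core to the other with the same size, and the gap between its two steps is larger than repeated measurements would explain: the same change on two cores in this assay, an at least 3.3-fold lower number (0.52 log units; beyond the scatter) from compound 1 to compound 3 and a 1.1-fold higher number (0.04 log units; within the scatter) from compound 2 to compound 4, at least 3.6-fold (0.56 log units) apart, beyond the scatter of two such steps

This shows that a step read on one core in this series is a poor guide to the same change on the other, but it does not show which feature of the cores sets the two steps apart, and the true size of the earlier step stays unknown, since compound 1 gives only a limit, not a number: the limit of > 50000 nM in this assay, at which 1 of the 4 values shown sits.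

The compounds shown leave open what this change does on further cores in the series, and whether the outcome on the core of compound 2 would hold with the trifluoromethoxy group placed elsewhere on its phenyl ring. They also leave open whether a methoxy group, an amine or a carboxylic acid in place of the hydroxyl group would give a number different from those of compound 2 and compound 4.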